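Sulfamate amide series: pyridinyl to phenyl on the amine

The source may hold more compounds than are shown below. What is called first, only, known or untested is meant among the compounds shown, and "the series" means these compounds.

Two compounds carry numbers. In an assay on HEK293 cells for inhibition of Steryl-sulfatase (Homo sapiens), tested at 1 uM (a lower number here means a weaker effect, a higher number a stronger effect of the compound at the concentration tested), compound 1 `NS(=O)(=O)Oc1ccc2c(c1)CN(C(=O)c1cccc(N3CCC(Cc4ccccc4)CC3)c1)CC2` gives 41.9%, while compound 2 `CCN(Cc1ccccn1)c1ccc(C(=O)N2CCc3ccc(OS(N)(=O)=O)cc3C2)cc1` gives 87.7%, the higher of the two values and beyond the scatter from compound 1. Compound 3 `CCN(Cc1ccccc1)c1ccc(C(=O)N2CCc3ccc(OS(N)(=O)=O)cc3C2)cc1` differs from compound 2 in one place: phenyl in place of pyridin-2-yl on a saturated chain carbon bound to a nitrogen on an aromatic ring. For the measured compounds named here, no step between measured compounds covers this kind of change. The replacement removes one hydrogen-bond acceptor, and the expected step of a number 5.7 percentage points lower from compound 2 to compound 3 (within the scatter) in this assay is small, toward a slightly weaker effect or none beyond the scatter. Compound 3 is estimated at 82%, within 65% to 95%.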

Compound 3, a percentage reported as inhibition, at one concentration (the size of the read-out at that concentration, not a potency): 83.6%
Compound 3: middle estimate off by 1.6 percentage points, on the low side, within the range that was stated.
By their numbers in this assay, from the lowest: compound 1; then compounds 3 and 2 (each within the scatter of the next).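

On a saturated chain carbon bound to a nitrogen on an aromatic ring, phenyl in place of pyridin-2-yl gives a number 4.1 percentage points lower from compound 2 to compound 3 (within the scatter) in this assay. The hydrogen-bond acceptor of pyridin-2-yl is therefore not required at this position to keep the read-out in this range. Nothing at hand bears on why the step is this small.

Still open, on these data alone, is how cyclohexyl or pyridin-4-yl would read at this place, or propyl in place of the ethyl of benzyl(ethyl)amino. As a read-out at one concentration, these numbers also leave the potencies of compound 2 and compound 3 undefined.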